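This account rests on a few compounds, and the source may have more. Where it says the series, first, only, none or still open, it means among the compounds named here.

Among the compounds with values here, in an assay on isolated protein for inhibition of glutathione S-transferase P (Homo sapiens), with a stated time of 10 min (on this read-out higher numbers stand for weaker inhibition and lower numbers for stronger inhibition), compound 2 `O=C(CCC(=O)OCCCCCCSc1ccc([N+](=O)[O-])c2nonc12)Nc1ccc(F)c(Cl)c1` gives 9850 nM, the higher of the two numbers so far. Within the data shown here, compound 1 `COc1ccc(NC(=O)CCC(=O)OCCCCCCSc2ccc([N+](=O)[O-])c3nonc23)cc1` gives 420 nM, and the single measured step, a 23-fold higher number from compound 1 to compound 2 (1.37 log units; beyond the scatter), shows how strongly the group on the amide nitrogen can move the read-out. Compound 3 `O=C(CCC(=O)OCCCCCCSc1ccc([N+](=O)[O-])c2nonc12)NCCN1CCCC1` carries a different kind of change: 2-(pyrrolidin-1-yl)ethyl in place of 3-chloro-4-fluorophenyl on an amide-type nitrogen. Among the measured compounds shown here, no measured step covers a swap of an aromatic group for a chain bearing a ring of this sort, so the only guide is that the amide substituent can shift the number by a large amount, as the step from compound 1 to compound 2 shows. Given that compound 2 already stands at the high end, the change is expected to run downward with wide uncertainty, and the expected step is a 3.3-fold lower number from compound 2 to compound 3 (0.52 log units; beyond the scatter). Compound 3 is therefore estimated at 3000 nM, within a range of 500 nM to 20000 nM.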

Compound 3, half-maximal inhibitory concentration: 460 nM
Compound 3: middle estimate off by 6.5-fold (0.81 log units), on the high side; the measured number lies below the stated range.
By their numbers in this assay, from the lowest: compounds 1 and 3 (each within the scatter of the next); then compound 2.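

In this assay the step of a 21-fold lower number from compound 2 to compound 3 (1.33 log units; beyond the scatter) is a second large one at the amide-type nitrogen, and it shows that a low number there does not require an aromatic ring on that nitrogen. The step of a 1.1-fold higher number from compound 1 to compound 3 (0.04 log units; within the scatter) lies within the scatter, so 4-methoxyphenyl and 2-(pyrrolidin-1-yl)ethyl cannot be told apart here, and among these three compounds only the 3-chloro-4-fluorophenyl of compound 2 stands apart. Nothing given here accounts for these differences.

On these data alone, it remains open whether the chlorine, the fluorine or both set compound 2 apart, which a plain phenyl or a phenyl carrying only one of these halogens could test. As far as these compounds go, it also remains open whether the pyrrolidine nitrogen matters, which a cyclopentylethyl group, a dimethylaminoethyl group or a carboxylic acid on a similar chain could test.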